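Acetyl to benzyloxycarbonyl exchange: working notes on the series

The source may report more compounds than this note shows. Statements on the series, on what has been measured and on what is new or still open speak of the compounds shown alone.

Measured so far:
- Compound 1 `CC(=O)NC(CCC(=O)NC(CSCc1ccc(Br)cc1)C(=O)NCC(=O)O)C(=O)O`: in a functional assay on K562 cells (Homo sapiens) for cytotoxicity (on this read-out higher numbers stand for weaker inhibition and lower numbers for stronger inhibition), compound 1 gives > 50 uM, which is a limit of the assay.
- Compound 2 `O=C(O)CNC(=O)C(CSCc1ccc(Br)cc1)NC(=O)CCC(NC(=O)OCc1ccccc1)C(=O)O`: in this assay compound 2 gives > 50 uM, again a limit.
- Compound 3 `COC(=O)CNC(=O)C(CSC(=O)OCc1ccccc1)NC(=O)CCC(NC(C)=O)C(=O)OC`: in this assay compound 3 gives > 50 uM, also a limit.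

All three values sit at the same point, (the limit of > 50 uM in this assay, at which 3 of the 3 values shown sit), so the step that the two limits leave unreadable from compound 1 to compound 2 has no readable size. The change behind that step is benzyloxy in place of methyl on a carbonyl carbon. Compound 4 `COC(=O)CNC(=O)C(CSC(=O)OCc1ccccc1)NC(=O)CCC(NC(=O)OCc1ccccc1)C(=O)OC` remains to be measured; it differs from compound 3 by benzyloxy in place of methyl on a carbonyl carbon, the same change as from compound 1 to compound 2, since the place lines agree word for word. How the cores of compound 1 and compound 3 differ is not broken down here.

With only limits available, nothing in the measured pair points either way. Within the data shown here, the expected step for compound 4 in this assay is a step that the limit leaves unreadable from compound 3 to compound 4, resting on (the limit of > 50 uM in this assay, at which 3 of the 3 values shown sit), at which every value so far stands. Compound 4 is therefore expected to give 100 uM, most likely reported as a limit, with a range of 40 uM to 300 uM allowed for.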

Compound 4, concentration for 50% inhibition: 1.26 uM
The estimate for compound 4 lay 79-fold (1.90 log units) above the measured number; the whole stated range lies above it.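

In this assay the change of acetyl to benzyloxycarbonyl gives an at least 39-fold lower number from compound 3 to compound 4 (1.59 log units; beyond the scatter), so on the core of compound 3 this change goes with much stronger inhibition. The same change on the core of compound 1 gives a step that cannot be read, because compound 1 and compound 2 both stand at a limit of the assay: the limit of > 50 uM in this assay, at which 3 of the 4 values shown sit. The measured pairs therefore show neither that the change carries from one core to the other nor that it fails to, and the large step holds only for compound 3 and compound 4.

The compounds shown leave open which part of the benzyloxy group goes with the step, for instance whether a plain ethoxy, a longer chain such as hexyloxy, or cyclohexylmethoxy on the same carbonyl carbon would give a number like that of compound 4. Also open, going by these compounds, is what a free amine in place of the acetamido group would give on the core of compound 3.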